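A few compounds are considered here, and "the series" means these few. Any claim that something is new, unique, unknown or untested is made for them only; others in the source may bear on it.

Of the compounds shown here, three have been measured in an ADME assay on S9 fraction from liver (Rattus norvegicus) for metabolic stability, read by LC-MS, using NADPH, with a stated time of 30 min (a higher number here means that more of the compound is left, a lower number that less of the compound is left), so far. Compound 1 `CCCCCCCCc1ccc(OCC(=O)Cn2cnnn2)cc1` gives 22% there. Compound 2 `CCCCCCCCc1ccc(OCC(=O)Cn2nnc(-c3cccc(C(=O)O)c3)n2)cc1` gives < 5% as a limit of the assay, not a number. Compound 3 `CCCCCCCCc1ccc(OCC(=O)Cn2nnnc2-c2ccc(Cl)cc2)cc1` gives 45% and so stands highest of the two actual numbers, with compound 1 the only other one. Among the measured compounds shown here, the single measured step, a number 23 percentage points higher from compound 1 to compound 3 (beyond the scatter) on bringing in 4-chlorophenyl in place of hydrogen on an aromatic carbon, is the only one that bears on what follows.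

Compound 4 `CCCCCCCCc1ccc(OCC(=O)Cn2nnnc2-c2cccc(S(=O)(=O)N(C)C)c2)cc1` differs from compound 3 as follows: 3-(dimethylsulfamoyl)phenyl in place of 4-chlorophenyl on an aromatic carbon and the rest of the structure stays the same. For the measured compounds named here, the step from compound 1 shows that this place can move the number by a modest amount, but it tested only one group. The downward lean rests on compound 2, another aryl-bearing structure, with its limit of < 5% in place of a number. In this assay the expected step is a number 12 percentage points lower from compound 3 to compound 4 (beyond the scatter) as a fall somewhat smaller than the measured rise. For compound 4 the estimated value is 33% with 14% to 55% as the expected range.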

Compound 4, percent of the compound remaining: 24%
Estimate against measurement, compound 4: 9 percentage points above; low and high end bracket the measured number.
By their numbers in this assay, from the lowest: compounds 1 and 4 (each within the scatter of the next); then compound 3. At a limit, below all of these: compound 2.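

In this assay, the aromatic carbon of the five-membered ring now carries two different phenyl groups, and they do not act alike. Replacing 4-chlorophenyl with 3-(dimethylsulfamoyl)phenyl gives a number 21 percentage points lower from compound 3 to compound 4 (beyond the scatter), so the gain seen earlier, a number 23 percentage points higher from compound 1 to compound 3 (beyond the scatter), does not extend to every phenyl group at this place. Set against hydrogen, 3-(dimethylsulfamoyl)phenyl gives a number 2 percentage points higher from compound 1 to compound 4 (within the scatter), which shows that a phenyl ring on this carbon does not by itself raise the number.

The change swaps the chlorine for the dimethylsulfamoyl group and also alters where the substituent sits on the phenyl ring, so the compounds shown leave open which of the two matters; a 3-chlorophenyl or a 4-(dimethylsulfamoyl)phenyl group would separate them, and an unsubstituted phenyl group would show what the ring alone does. Compound 2 stands at a limit and not a number, and it differs from the other compounds in more than one place, so it adds no step at this position: the limit of < 5% in this assay, at which 1 of the 4 values shown sits.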